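The compounds below may be only part of what the source reports. "The series", "measured", "known", "first", "only" and "open" are said of these compounds alone.

Measured compounds in a functional assay (aorta) with Oryctolagus cuniculus as the target; a lower number here means tighter binding, a higher number weaker binding:
- compound 1 `COc1cc(C(C)=O)ccc1OCCCN1CCC(C(c2ccc(F)cc2)C2CCCCC2)CC1` gives 5.01 nM
- compound 2 `COc1cc(C(C)=O)ccc1OCCCN1CCC(C(c2ccc(F)cc2)c2ccccn2)CC1` gives 158 nM
- compound 3 `CCc1ccc(OCCCN2CCC(C(c3ccc(F)cc3)c3ccc(F)cc3)CC2)c(OC)c1` gives 2.51 nM

Compound 3 shows the lowest of the three numbers in this assay. Its nearest neighbour is compound 1, whose number lies within the scatter of compound 3, so no order between these two can be stated. Compound 2 lies furthest away, beyond the scatter. Going by the values given here, the one single-point step that has been measured, a 32-fold higher number from compound 1 to compound 2 (1.50 log units; beyond the scatter), sits at the saturated chain carbon bound to an aromatic carbon and a saturated ring carbon, at the opposite end of the shared core from the aryl ether.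

Compound 4 `CC(=O)Nc1ccc(OCCCN2CCC(C(c3ccc(F)cc3)c3ccc(F)cc3)CC2)cc1` differs from compound 3 by 4-acetamidophenyl in place of 4-ethyl-2-methoxyphenyl on an oxygen on a saturated carbon. Among the compounds with values here, no measured step touches this part of the structure: compound 1 and compound 3 differ from each other in two places at once, so their two values show only that both lie within the scatter of one another. Within the data shown here, the change to compound 4 therefore rests on no precedent in this set. Compound 4 is expected to give a somewhat higher number, with wide uncertainty, estimated as a 3.2-fold higher number from compound 3 to compound 4 (0.50 log units; beyond the scatter). The estimate for compound 4 in this assay is 8 nM, expected between 2 nM and 40 nM.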

Compound 4, dissociation constant: 12.6 nM
Beside the measured number, compound 4's estimate is 1.6-fold (0.20 log units) below it; the measured number falls inside the stated range.
By their numbers in this assay, from the lowest: compounds 3 and 1 (each within the scatter of the next); then compound 4; then compound 2.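

At the position on an oxygen on a saturated carbon, 4-acetamidophenyl in place of 4-ethyl-2-methoxyphenyl gives a 5.0-fold higher number from compound 3 to compound 4 (0.70 log units; beyond the scatter) in this assay, so this part of the structure now has a measured step of its own: beyond the scatter but modest, and smaller than a 32-fold higher number from compound 1 to compound 2 (1.50 log units; beyond the scatter) at the saturated chain carbon. Both groups hold 10 heavy atoms and one six-membered aromatic ring of carbon only, while the entering group adds a hydrogen-bond donor and a double bond outside aromatic rings, and with these differences compound 4 still gives 12.6 nM. Nothing in hand offers a reason for the size of this step.

The step removes the methoxy and ethyl groups and brings in the acetamido group all at once, so the compounds shown do not separate what each of these contributes. Also open, going by these compounds, is how this position responds to a sulfonamide or a carboxylic acid in place of the acetamido group, and to a longer chain bearing the aryl ether.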